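Methoxy to methyl on the benzyl sulfanyl group

This account rests on a few compounds, and the source may have more. Where it says the series, first, only, none or still open, it means among the compounds named here.

Values in a functional assay on RAW264.7 cells (Mus musculus) for inhibition, with stated times of 2 h and 24 h; a higher number here means a weaker inhibitor, a lower number a stronger inhibitor:
compound 1 `COc1ccc([C@@H]2c3c(OC)cc(OC)cc3/C(=C/c3ccc(Cl)cc3)[C@H]2c2cc(OC)cc(OC)c2)cc1`: > 200000 nM (a limit)
compound 2 `COc1ccc(CSC2c3cc(OC)cc(OC)c3[C@@H](c3ccc(OC)cc3)[C@@H]2c2cc(OC)cc(OC)c2)cc1`: 12500 nM
compound 3 `COc1ccc(CSC2c3cc(OC)cc(OC)c3[C@@H](c3ccccc3)[C@@H]2c2cc(OC)cc(OC)c2)cc1`: > 200000 nM (a limit)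

Among the compounds with values here, compound 2 gives the only actual number in this assay, and the other two values stand at the limit of > 200000 nM in this assay, at which 2 of the 3 values shown sit. Compound 4 `COc1ccc([C@@H]2c3c(OC)cc(OC)cc3C(SCc3ccc(C)cc3)[C@H]2c2cc(OC)cc(OC)c2)cc1` carries methyl in place of methoxy on an aromatic carbon, turning 4-methoxybenzyl into 4-methylbenzyl: methyl in place of methoxy on an aromatic carbon. Within the data shown here, the only measured step that bears on it is an at least 16-fold higher number from compound 2 to compound 3 (1.20 log units; beyond the scatter), a methoxy lost elsewhere with the 4-methoxybenzyl group kept, so only a much smaller rise is expected in this assay, perhaps none beyond the scatter. The expected step is a 1.6-fold higher number from compound 2 to compound 4 (0.20 log units; within the scatter). Compound 4 is estimated at 20000 nM, with an expected range of 6000 nM to 100000 nM.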

Compound 4, half-maximal inhibitory concentration: > 200000 nM
Compound 4: only a limit was reported; the forecaster's own chance of this, stated with the estimate: 20%; middle value at least 10-fold (1.00 log units) from the limit.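

In this assay the change from (4-methoxybenzyl)sulfanyl to (4-methylbenzyl)sulfanyl gives an at least 16-fold higher number from compound 2 to compound 4 (1.20 log units; beyond the scatter), so this methoxy counts as well as the one lost in an at least 16-fold higher number from compound 2 to compound 3 (1.20 log units; beyond the scatter). Of the sulfanyl compounds shown, only compound 2 carries both methoxy groups, and only compound 2 gives an actual number. Compound 4 gives only a limit: the limit of > 200000 nM in this assay, at which 3 of the 4 values shown sit.

On these data alone, the true size of this step stays open. So does whether a hydroxyl, an ethoxy or an amine on this aromatic carbon could stand in for the methoxy.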